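Chalcone series: moving fluorine on the aryl of compound 2

A few compounds are considered here, and "the series" means these few. Any claim that something is new, unique, unknown or untested is made for them only; others in the source may bear on it.

Measured compounds, with their values in an assay on isolated protein for inhibition of Amine oxidase [flavin-containing] B (Homo sapiens); a lower number here means a stronger inhibitor, a higher number a weaker inhibitor:
Compound 1 `CCOc1ccc(C(=O)/C=C/c2ccc(C)cc2)cc1`: 210 nM.
Compound 2 `O=C(/C=C/c1cccc(F)c1)c1ccc(-n2ccnc2)cc1`: > 10000 nM, which is a limit of the assay.
Compound 3 `O=C(/C=C/c1ccc(ON=C(c2ccccc2)c2ccccc2)cc1)c1ccc(F)cc1`: < 50 nM, which is a limit of the assay.

Compound 2 thus stands at the weak end of the three values shown: its result is only a limit, (the limit of > 10000 nM in this assay, at which 1 of the 3 values shown sits), and no number is known for it. The unmeasured compound 4 `O=C(/C=C/c1ccccc1F)c1ccc(-n2ccnc2)cc1` differs from compound 2 in one place: 2-fluorophenyl in place of 3-fluorophenyl on a double-bonded chain carbon bound to a double-bonded chain carbon. No step between measured compounds is shown for a change of this kind, so no direction can be read from the data. The expectation is that compound 4 stays near the same limit, a step from compound 2 to compound 4 of a step that the limit leaves unreadable from compound 2 to compound 4, that is none beyond the scatter. Compound 4 is estimated at 15000 nM, within 4000 nM to 60000 nM, most likely reported again as a limit.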

Compound 4, half-maximal inhibitory concentration: > 10000 nM
Compound 4: a limit, no number; the forecaster's own chance of this, stated with the estimate: 75%; the middle value does not contradict the limit.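

Among these compounds, compound 2 and compound 4 both remain limits of the assay in this assay, so no step between them can be read. The compounds shown leave open how 2-fluorophenyl and 3-fluorophenyl compare in numbers.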